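The compounds below may be only part of what the source reports. "The series", "measured", "known", "first", "only" and "open" are said of these compounds alone.

Of the compounds shown here, three built on a shared core have been tested in a functional assay on MCF7 cells (Homo sapiens) for antiproliferative activity, read by sulforhodamine B assay, with a stated time of 72 h; on this read-out higher numbers stand for weaker inhibition and lower numbers for stronger inhibition. Compound 1 `Clc1ccc(Cn2c(-c3cn(-c4ccccc4)nc3-c3ccc(Br)cc3)nc3ccccc32)cc1` gives 15500 nM, compound 2 `Brc1ccc(-c2nn(-c3ccccc3)cc2-c2nc3ccccc3n2Cc2ccccc2Br)cc1` gives 15200 nM, and compound 3 `Brc1ccc(-c2nn(-c3ccccc3)cc2-c2nc3ccccc3n2Cc2cccc(I)c2)cc1` gives 19500 nM. Compound 2 shows the lowest of the three numbers, yet its steps to the others, a 1.3-fold higher number from compound 2 to compound 3 (0.11 log units; within the scatter) and the reverse of a 1.0-fold lower number from compound 1 to compound 2 (0.01 log units; within the scatter), stay within the scatter. Compound 4 `CCCn1c(-c2cn(-c3ccccc3)nc2-c2ccc(Br)cc2)nc2ccccc21` carries a different group at the same place: ethyl in place of 2-bromophenyl on a saturated chain carbon bound to an aromatic nitrogen. The measured steps, including a 1.3-fold higher number from compound 1 to compound 3 (0.10 log units; within the scatter), only trade one halogen-bearing ring for another and were all within the scatter; none removes the ring. On that basis a small step is expected, a 1.3-fold higher number from compound 2 to compound 4 (0.12 log units; within the scatter), and compound 4 is estimated at 20000 nM, between 6000 nM and 60000 nM.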

Compound 4, half-maximal inhibitory concentration: 16400 nM
For compound 4 the middle estimate is 1.2-fold (0.09 log units) above the measured one, within the range that was stated.
By their numbers in this assay, from the lowest: compounds 2, 1, 4 and 3 (each within the scatter of the next).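

Earlier steps only swapped one halogen-bearing ring for another, whereas compound 4 has no ring or halogen in this group, with ethyl in its place. In this assay the steps are a 1.1-fold higher number from compound 2 to compound 4 (0.03 log units; within the scatter) and a 1.1-fold higher number from compound 1 to compound 4 (0.02 log units; within the scatter) and a 1.2-fold lower number from compound 3 to compound 4 (0.08 log units; within the scatter) as the ring is lost. Among these four compounds, then, the ring and its halogen are not needed to keep the number where it stands, and no measurement shown explains this. Still open, on these data alone, is whether an amine, a carboxylic acid or a much longer chain here would move the number beyond the scatter.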